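Chloro for trifluoromethyl in the two-place-differing pair

The source may report more compounds than this note shows. Statements on the series, on what has been measured and on what is new or still open speak of the compounds shown alone.

Compound 2 `Cc1cc(=O)n(-c2ccccc2C(F)(F)F)nc1C(=O)Nc1ccc(Oc2ncnc3c2ccn3C)c(F)c1` gives 35400 nM in a functional assay on A549 cells (Homo sapiens) for cytotoxicity, read by MTT assay, with a stated time of 72 h (on this read-out lower numbers stand for stronger inhibition and higher numbers for weaker inhibition), and stands highest of the two numbers in hand. Compound 1 `Cc1cc(=O)n(-c2ccccc2Cl)nc1C(=O)Nc1ccc(Oc2ncnc3c2ccn3C)cc1` gives 5120 nM in this assay, a number beyond the scatter below that of compound 2; the two compounds differ in two places, so no single step can be read between them, and only their two values are known. Compound 3 `Cc1cc(=O)n(-c2ccccc2Cl)nc1C(=O)Nc1ccc(Oc2ncnc3c2ccn3C)c(F)c1` is not yet measured. It arises from compound 2 by chloro in place of trifluoromethyl on an aromatic carbon. Compound 3 carries the same chloro group as compound 1 and shares the rest of its structure with compound 2. For compound 3 the expected step in this assay is a 3.9-fold lower number from compound 2 to compound 3 (0.59 log units; beyond the scatter), a drop beyond the scatter, because compound 1 with the chloro group gives 5120 nM. Compound 3 is therefore estimated at 9000 nM, within a range of 3000 nM to 27000 nM.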

Compound 3, half-maximal inhibitory concentration: > 60000 nM
Compound 3: a limit, no number (the forecaster's own chance of this, stated with the estimate: 5%); middle value at least 6.6-fold (0.82 log units) from the limit.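

In this assay, compound 3 stands at a limit of the assay, not a number: the limit of > 60000 nM in this assay, at which 1 of the 3 values shown sits. Chloro in place of trifluoromethyl on this aromatic carbon gives an at least 1.6-fold higher number from compound 2 to compound 3 (0.22 log units; that floor lies within the scatter), so with fluoro on the other ring position held constant, the chloro group does not bring the lower number that compound 1 had suggested. Fluoro in place of hydrogen on an aromatic carbon gives an at least 11-fold higher number from compound 1 to compound 3 (1.06 log units; beyond the scatter), the first single-place step in the series, and it shows that with chloro held constant this one atom moves the read-out beyond the scatter.

From the compounds shown here alone, how far the number for compound 3 lies past its limit stays open, and so does the size of the fluoro step with trifluoromethyl in place. Also open, going by these compounds, is how an amine or a methoxy group would read on this aromatic carbon.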